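The source may report more compounds than this note shows. Statements on the series, on what has been measured and on what is new or still open speak of the compounds shown alone.

Working notes on the series. Of the compounds shown here, two sharing one core have been measured in an assay on isolated protein for inhibition of Indoleamine 2,3-dioxygenase 1 (Homo sapiens), read by HPLC, with a stated time of 60 min, in the presence of a further agent that is not named here; on this read-out lower numbers stand for stronger inhibition and higher numbers for weaker inhibition. Compound 1 `COc1ccccc1Sc1c[nH]c2ccc(F)cc12` gives 32000 nM in this assay. Compound 2 `COc1ccccc1Sc1c[nH]c2ccc(Br)cc12` gives 24000 nM in this assay. Among the compounds with values here, the only step between them, a 1.3-fold lower number from compound 1 to compound 2 (0.12 log units; within the scatter), is a halogen swap that leaves the number essentially unchanged. Compound 2 holds the lower of the two numbers, but with compound 1 within the scatter no order between them can be claimed.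

Compound 3 `COc1ccccc1Sc1c[nH]c2ccc(I)cc12` is not yet measured. It differs from compound 2 by iodo in place of bromo on an aromatic carbon. Within the data shown here, the one step that bears on this change, a 1.3-fold lower number from compound 1 to compound 2 (0.12 log units; within the scatter), was within the scatter, so for the next halogen step in this assay no shift beyond the scatter is expected, with at most a slight drift toward a lower number. Compound 3 is therefore estimated at 20000 nM in this assay, within 8000 nM to 50000 nM, which means an expected step of a 1.2-fold lower number from compound 2 to compound 3 (0.08 log units; within the scatter).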

Compound 3, half-maximal inhibitory concentration: 45000 nM
For compound 3 the middle estimate is 2.3-fold (0.35 log units) below the measured one; the range from low to high includes it.
By their numbers in this assay, from the lowest: compounds 2, 1 and 3 (each within the scatter of the next).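

In this assay, this aromatic carbon now carries three different halogens, and both new steps stay within the scatter (a 1.9-fold higher number from compound 2 to compound 3 (0.27 log units; within the scatter); a 1.4-fold higher number from compound 1 to compound 3 (0.15 log units; within the scatter)). The first step alone left room for a slow drift along the halogens, but with iodo in place no trend from fluoro through bromo to iodo can be claimed, and compounds 1, 2 and 3 cannot be put in any order. The position has so far shown no response to exchange of one halogen for another, and no supporting evidence bears on this result.

On these data alone, whether anything other than a halogen at this carbon, such as an amine, a carboxylic acid or a longer alkyl chain, would move the number beyond the scatter remains open. Also open, as far as these compounds go, is whether the flat reading holds for halogen exchange on a core altered elsewhere.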